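The compounds below may be only part of what the source reports. "The series", "measured", "known", "first", "only" and "open" are said of these compounds alone.

Going by the values given here, in a toxicity assay on NIH3T3 cells (Mus musculus) for cytotoxicity, read by resazurin assay (a lower number here means that less compound is needed, a higher number that more compound is needed for the effect), compound 2 `COC(=O)c1ccc(NCc2cncn2Cc2ccccc2N)cc1-c1ccccc1` gives 25000 nM, the only exact number available so far. Compound 1 `COC(=O)c1ccc(NCc2cncn2Cc2ccc(N)cc2)cc1-c1ccccc1` gives > 10000 nM, which is a limit of the assay and not a number. Compound 3 `COC(=O)c1ccc(NCc2cncn2Cc2ccc([N+](=O)[O-])cc2)cc1-c1ccccc1` keeps the shared core of compound 2 but carries 4-nitrophenyl in place of 2-aminophenyl on a saturated chain carbon bound to an aromatic nitrogen. Among the compounds with values here, only one measured step touches this same place, a step that the limit leaves unreadable from compound 1 to compound 2, and it has no readable size, since it rests on (the limit of > 10000 nM in this assay, at which 1 of the 2 values shown sits). With no measured size or direction to carry over from that step, no change beyond the scatter is expected in this assay. The estimated step is no change at the digits printed from compound 2 to compound 3 (within the scatter). For compound 3 the expected value is 25000 nM, with an estimated range from 8000 nM to 70000 nM.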

Compound 3, half-maximal effective concentration: > 10000 nM
Compound 3: no number, only a limit; the forecaster's own chance of this, stated with the estimate: 40%; the middle value lies beyond the limit too.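

In this assay compound 3 gives > 10000 nM which is a limit of the assay and not a number. The steps among compound 1, compound 2 and compound 3 therefore cannot be read: the limit of > 10000 nM in this assay, at which 2 of the 3 values shown sit. On these data alone, how far 4-aminophenyl or 4-nitrophenyl differs from 2-aminophenyl in this cytotoxicity read-out stays open.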